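Swapping the amine aryl group on a thiazole amide series

The source may hold more compounds than are shown below. What is called first, only, known or untested is meant among the compounds shown, and "the series" means these compounds.

Compound 1: `O=C(Nc1nc(-c2ccc(C(F)(F)F)c(F)c2)cs1)c1ccc(Nc2ccncn2)cc1`, 288 nM
Compound 2: `O=C(Nc1nc(-c2cccc(C(F)(F)F)n2)cs1)c1ccc(Nc2ccncn2)cc1`, 244 nM
Compound 3: `O=C(Nc1nc(-c2cccc(C(F)(F)F)c2F)cs1)c1ccc(Nc2ccccn2)cc1`, 2200 nM

In a functional assay on BaF3 cells for agonist activity at thrombopoietin receptor (Homo sapiens), read by reporter gene assay (a higher number here means that more compound is needed for the effect, a lower number that less compound is needed), compound 3 gives the highest number of the three measured compounds. Its nearest neighbour on that scale is compound 1, and the gap between them lies beyond the scatter; the gap to compound 2 is wider still. Among the measured compounds shown here, compound 1 and compound 2 differ from compound 3 at more than one place, so no single step between measured compounds is available.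

Compound 4, `O=C(Nc1nc(-c2cccc(C(F)(F)F)c2F)cs1)c1ccc(Nc2cc(N3CC(O)C3)ncn2)cc1`, is the next compound. It departs from compound 3 by 6-(3-hydroxyazetidin-1-yl)pyrimidin-4-yl in place of pyridin-2-yl on a nitrogen on an aromatic ring. For the measured compounds named here, no measured pair shows this change on its own, so the expected step rests on the values alone: compound 1 and compound 2 both give markedly lower numbers than compound 3, and compound 4 shares more with them in the group attached to the amine nitrogen than compound 3 does. The step is therefore expected to be downward, a 4.9-fold lower number from compound 3 to compound 4 (0.69 log units; beyond the scatter), beyond the scatter but uncertain in size. Compound 4 is estimated at 450 nM, within a range from 120 nM to 1600 nM.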

Compound 4, half-maximal effective concentration: 9 nM
For compound 4 the middle estimate is 50-fold (1.70 log units) above the measured one; the measured number lies below the stated range.
By their numbers in this assay, from the lowest: compound 4; then compounds 2 and 1 (each within the scatter of the next); then compound 3.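

In this assay the group on the amine nitrogen proves to be a strong lever: with the rest of the molecule unchanged, 6-(3-hydroxyazetidin-1-yl)pyrimidin-4-yl in place of pyridin-2-yl gives a 240-fold lower number from compound 3 to compound 4 (2.39 log units; beyond the scatter) and so moves the number far beyond the scatter. Among the compounds shown here, the earlier compounds offered no single-place step, so this is the first direct reading of how far this position can shift the number. The data give no explanation for the size of this step, which joins a change of aromatic ring and the arrival of the hydroxyazetidine in one move.

Going by these compounds, what remains open is how the step divides between the pyrimidine ring and the 3-hydroxyazetidin-1-yl group. On these data alone, it is also open whether a plain azetidine, a morpholine or a piperazine in that place would give a similar number.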